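Diisopropylamino for 4-Methylpiperazin-1-yl: Compound 4 Expected

The source may hold more compounds than are shown below. What is called first, only, known or untested is meant among the compounds shown, and "the series" means these compounds.

Compound 1, `Cc1ccc(N2CCN(C(=O)C3CCN(C(=O)c4ccc(S(C)(=O)=O)c([N+](=O)[O-])c4)CC3)CC2)cc1`, reaches only the assay limit in an assay on isolated protein for inhibition of thyroid hormone receptor alpha (Homo sapiens), read by fluorescence polarization (on this read-out higher numbers stand for weaker inhibition and lower numbers for stronger inhibition), recorded as > 60000 nM. Compound 2, `CN1CCN(C(=O)CNC(=O)c2ccc(S(C)(=O)=O)c([N+](=O)[O-])c2)CC1`, likewise shows only a limit in this assay, recorded as > 60000 nM. Compound 3, `CS(=O)(=O)c1ccc(C(=O)N2CCC(C(=O)N(Cc3ccccc3)Cc3ccccc3)CC2)cc1[N+](=O)[O-]`, also gives only a limit in this assay, recorded as > 60000 nM.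

Compound 2 thus stands where every measured compound stands: on (the limit of > 60000 nM in this assay, at which 3 of the 3 values shown sit). Among the measured compounds shown here, no step between measured compounds is available, so nothing can be said of any real difference among them beyond the fact that all three share that limit.

Compound 4, `CC(C)N(C(=O)CNC(=O)c1ccc(S(C)(=O)=O)c([N+](=O)[O-])c1)C(C)C`, keeps the shared core and changes one place: diisopropylamino in place of 4-methylpiperazin-1-yl on a carbonyl carbon. For the measured compounds named here, with no measured step to lean on, the expectation for the move from compound 2 is a change in this assay no larger than the scatter, in no particular direction, and most likely another limit. The expected step that the limit leaves unreadable from compound 2 to compound 4 is, in this reading, not beyond the scatter. Compound 4 is therefore expected to give 90000 nM, with a range from 30000 nM to 300000 nM.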

Compound 4, half-maximal inhibitory concentration: > 60000 nM
Compound 4 gave a limit, no number (the forecaster's own chance of this, stated with the estimate: 85%); the middle value does not contradict the limit.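

Compound 2 and compound 4 both give only a limit, so no step can be read between them: the limit of > 60000 nM in this assay, at which 4 of the 4 values shown sit.

The compounds shown leave open whether any change to the shared core gives a measurable number in this assay, and how the four compounds truly compare.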